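Swapping one fluoro for hydrogen on compound 2

This account rests on a few compounds, and the source may have more. Where it says the series, first, only, none or still open, it means among the compounds named here.

Compound 1 `O=C(N/N=C/c1cccc(Br)c1)Nc1ccc(Oc2ccnc3[nH]ccc23)c(F)c1` gives 660 nM
Compound 2 `O=C(N/N=C/c1ccc(Br)cc1)Nc1ccc(Oc2ccnc3[nH]ccc23)c(F)c1` gives 1000 nM
Compound 3 `O=C(N/N=C/c1ccc(F)cc1Cl)Nc1ccc(Oc2ccnc3[nH]ccc23)c(F)c1` gives 1110 nM

These values come from a functional assay on HepG2 cells (Homo sapiens) for antiproliferative activity, read by MTT assay, with a stated time of 72 h (a lower number here means a stronger inhibitor, a higher number a weaker inhibitor), and compound 2 is not clearly separated from the other two, as the steps of a 1.5-fold higher number from compound 1 to compound 2 (0.18 log units; within the scatter) and a 1.1-fold higher number from compound 2 to compound 3 (0.05 log units; within the scatter) show. Compound 4 `O=C(N/N=C/c1ccc(Br)cc1)Nc1ccc(Oc2ccnc3[nH]ccc23)cc1` is still unmeasured. It differs from compound 2 by hydrogen in place of fluoro on an aromatic carbon with hydrogen in place of fluoro on an aromatic carbon of a six-membered aromatic ring of carbon only. For the measured compounds named here, no measured step touches this place: those two, like a 1.7-fold higher number from compound 1 to compound 3 (0.23 log units; within the scatter) only swap the aryl group on a carbon with a double bond to nitrogen. They therefore give no direction. The expected step is no change at the digits printed from compound 2 to compound 4 (within the scatter) in this assay which means none beyond the scatter. Compound 4 is expected at 1000 nM with an estimated range of 400 nM to 2500 nM for now.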

Compound 4, half-maximal inhibitory concentration: 1000 nM
Compound 4: the middle estimate sits on the measured number at the digits printed; measured number inside the range.
By their numbers in this assay, from the lowest: compounds 1, 2, 4 and 3 (each within the scatter of the next).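

In this assay, hydrogen in place of fluoro on this aromatic carbon gives no change at the digits printed from compound 2 to compound 4 (within the scatter). For the compounds shown here, this is the first look at this place, and with the 4-bromophenyl group present, the fluoro makes no difference that can be told from the scatter. No available measurement explains this result.

The swap is shown only with 4-bromophenyl, so whether it behaves the same with 3-bromophenyl or 2-chloro-4-fluorophenyl remains open. Also open, as far as these compounds go, is what a methoxy group or an amine on this carbon would do.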